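Replacing an Ester Arm with a Nitrobenzyl Arm

The source may report more compounds than this note shows. Statements on the series, on what has been measured and on what is new or still open speak of the compounds shown alone.

Compound 1 `C=CCn1c(=O)n(C2CN(CCCC)CC(CO)O2)c2nc(N)nc(O)c21`: 5 uM
Compound 2 `CCOC(=O)Cn1c(=O)n(C2OC(CO)[C@@H](O)[C@H]2O)c2nc(N)nc(O)c21`: 48 uM
Compound 3 `C=CCn1c(=S)n(C2OC(CO)[C@@H](O)C(O)[C@H]2O)c2nc(N)nc(O)c21`: 1 uM

All three compounds share a common core and were tested in a functional assay (B cells) with Mus musculus as the target; on this read-out higher numbers stand for an effect only at larger amounts of compound and lower numbers for an effect already at smaller amounts. Among the measured numbers, compound 2 stands highest: its nearest neighbour is compound 1, its furthest is compound 3, and both gaps lie beyond the scatter of repeated measurements. Within the data shown here, compound 1 and compound 3, however, differ from compound 2 in more than one place at once, so no single structural step between measured compounds can be read from these numbers.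

Compound 4 `Nc1nc(O)c2c(n1)n(C1OC(CO)[C@@H](O)[C@H]1O)c(=O)n2Cc1ccc([N+](=O)[O-])cc1` has not been measured yet. It differs from compound 2 in one place: 4-nitrophenyl in place of ethoxycarbonyl on a saturated chain carbon bound to an aromatic nitrogen. Among the measured compounds shown here, no measured step covers this change, so the expectation rests on a loose comparison only. Compound 1 with 5 uM and compound 3 with 1 uM carry a group other than ethoxycarbonyl on that chain carbon and give lower numbers, though each differs elsewhere too. For compound 4 the estimated step is a 3.2-fold lower number from compound 2 to compound 4 (0.51 log units; beyond the scatter). This expectation remains uncertain. For compound 4 a value of 15 uM is estimated, within a range from 3 uM to 60 uM.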

Compound 4, concentration for half-maximal effect: 40 uM
The estimate for compound 4 lay 2.7-fold (0.43 log units) below the measured number; the range from low to high includes it.
By their numbers in this assay, from the lowest: compound 3; then compound 1; then compounds 4 and 2 (each within the scatter of the next).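

In this assay, among these compounds, this is the first single-place step that can be read at this position: going from (ethoxycarbonyl)methyl to 4-nitrobenzyl gives a 1.2-fold lower number from compound 2 to compound 4 (0.08 log units; within the scatter). That step lies within the scatter of repeated measurements, so on this read-out the two arms cannot be told apart. Among the compounds shown here, at this saturated chain carbon bound to an aromatic nitrogen, then, an open-chain ester group and a larger group carrying a six-membered aromatic ring of carbon only read alike, something the earlier compounds could not show because each differs from compound 2 in more than one place. Nothing measured on these compounds gives a reason for this result.

From the compounds shown here alone, only these two arms can be compared directly here, so it remains open whether a plain benzyl group, a carboxylic acid, an amine or a longer chain at this place would shift the number beyond the scatter. Going by these compounds, it also remains open whether the same exchange would read alike on the core of compound 1 or the core of compound 3.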